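The source may report more compounds than this note shows. Statements on the series, on what has been measured and on what is new or still open speak of the compounds shown alone.

Measured compounds:
- compound 1 `COc1ccc(CNC(=O)/C=C/C=C/[C@H](O)Cc2ccc(OC)c(OC)c2)cc1`: 17400 nM
- compound 2 `COc1ccc(C[C@@H](O)/C=C/C=C/C(=O)N2CCN(c3ccccc3)CC2)cc1OC`: 9430 nM

In a functional assay on IMR-32 cells (Homo sapiens) for antiproliferative activity, read by sulforhodamine B assay, with a stated time of 48 h (on this read-out lower numbers stand for stronger inhibition and higher numbers for weaker inhibition), compound 2 and compound 1 sit within the scatter of each other; compound 2 cannot be set apart from compound 1 on these two numbers. Compound 3 `COc1ccc(C[C@@H](O)/C=C/C=C/C(=O)N2CCN(C)CC2)cc1OC` is not yet measured. It differs from compound 2 by methyl in place of phenyl on an amine nitrogen in a ring. For the measured compounds named here, no measured step of this kind stands, so the direction rests on nothing more than the change itself. A step in this assay from compound 2 to compound 3 of a 1.5-fold higher number from compound 2 to compound 3 (0.17 log units; within the scatter) is expected, toward a higher number, likely no larger than the scatter. Compound 3 is estimated at 14000 nM, within 5000 nM to 45000 nM.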

Compound 3, half-maximal inhibitory concentration: 18900 nM
For compound 3 the middle estimate is 1.4-fold (0.13 log units) below the measured one; the measured number falls inside the stated range.
By their numbers in this assay, from the lowest: compounds 2, 1 and 3 (each within the scatter of the next).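

For the compounds shown here, at the amine nitrogen in the ring, methyl in place of phenyl gives a 2.0-fold higher number from compound 2 to compound 3 (0.30 log units; within the scatter) in this assay, the first measured step at this position. On this step the two groups cannot be told apart, so the six-membered aromatic ring of carbon only is not shown to matter to this read-out. Nothing measured here bears on the reason for this.

Open, as far as these compounds go, is whether benzyl, acetyl or the free secondary amine on this nitrogen would give a number beyond the scatter of compound 2.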